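Working notes: 5-methylfuran-2-yl in place of 2,5-dimethoxyphenyl

A few compounds are considered here, and "the series" means these few. Any claim that something is new, unique, unknown or untested is made for them only; others in the source may bear on it.

Measured in a functional assay on A549 cells (Homo sapiens) for inhibition, read by sulforhodamine B assay, with a stated time of 48 h; a higher number here means a weaker inhibitor of growth, a lower number a stronger inhibitor of growth
- compound 1 `COc1ccc(/C=C/C(=O)C(=Cc2ccc(N(C)C)cc2)C(=O)/C=C/c2ccc(OC)c(OC)c2)cc1OC` gives 2620 nM
- compound 2 `COc1ccc(OC)c(C=C(C(=O)/C=C/c2ccc(OC)c(OC)c2)C(=O)/C=C/c2ccc(OC)c(OC)c2)c1` gives 530 nM

Compound 2 holds the lower of the two numbers in this assay, with compound 1 as its nearest neighbour. In compound 3 (`COc1ccc(/C=C/C(=O)C(=Cc2ccc(C)o2)C(=O)/C=C/c2ccc(OC)c(OC)c2)cc1OC`), 5-methylfuran-2-yl takes the place of the 2,5-dimethoxyphenyl of compound 2 on a double-bonded chain carbon bound to a double-bonded chain carbon (5-methylfuran-2-yl in place of 2,5-dimethoxyphenyl on a double-bonded chain carbon bound to a double-bonded chain carbon). Among the measured compounds shown here, the only measured step at this place is a 4.9-fold lower number from compound 1 to compound 2 (0.69 log units; beyond the scatter), modest in size and beyond the scatter. For the measured compounds named here, no measured compound carries 5-methylfuran-2-yl, so this single step gives only a rough scale. With compound 2 at the low end of the series at 530 nM, a modest step toward a higher number is expected. The expected step is a 1.9-fold higher number from compound 2 to compound 3 (0.28 log units; within the scatter). The estimate for compound 3 is 1000 nM, with an expected range of 350 nM to 3000 nM.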

Compound 3, concentration for 50% growth inhibition: 1310 nM
Beside the measured number, compound 3's estimate is 1.3-fold (0.12 log units) below it; measured number inside the range.
By their numbers in this assay, from the lowest: compound 2; then compounds 3 and 1 (each within the scatter of the next).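

In this assay, the position on a double-bonded chain carbon bound to a double-bonded chain carbon now also holds a five-membered aromatic ring, and 5-methylfuran-2-yl in place of 2,5-dimethoxyphenyl gives a 2.5-fold higher number from compound 2 to compound 3 (0.39 log units; beyond the scatter). Compound 2 therefore keeps the lowest number, with its steps to both other compounds beyond the scatter. Set against 4-(dimethylamino)phenyl, 5-methylfuran-2-yl gives a 2.0-fold lower number from compound 1 to compound 3 (0.30 log units; within the scatter), so these two groups are not separated here, and nothing measured on this series accounts for either step.

The compounds shown do not tell whether both methoxy groups of 2,5-dimethoxyphenyl are tied to the lower number, since a plain phenyl or a single-methoxy phenyl stands outside this set. Nor do they separate the methyl of 5-methylfuran-2-yl from the furan ring itself, which an unsubstituted furan-2-yl would address.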